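Nitro in Place of Trifluoromethyl: What to Expect for Compound 4

This account rests on a few compounds, and the source may have more. Where it says the series, first, only, none or still open, it means among the compounds named here.

Compound 1 `CC1=CCCC(C)(C)C1/C=C/C(=O)/C=C/c1cccc(C(F)(F)F)c1` gives 4400 nM in a functional assay on LNCaP C4-2B cells (Homo sapiens) for cytotoxicity, read by MTT assay, with a stated time of 72 h (a lower number here means a stronger inhibitor, a higher number a weaker inhibitor), the lowest of the three numbers measured, while compound 3 `CC1=CCCC(C)(C)C1/C=C/C(=O)/C=C/c1cc(C(F)(F)F)ccc1F` gives 4700 nM and compound 2 `CC1=CCCC(C)(C)C1/C=C/C(=O)/C=C/c1ccc(C(F)(F)F)cc1` gives 5200 nM, both within the scatter of compound 1. Going by the values given here, the only single-change step measured, a 1.1-fold higher number from compound 1 to compound 3 (0.03 log units; within the scatter), lies within the scatter. Compound 4 `CC1=CCCC(C)(C)C1/C=C/C(=O)/C=C/c1cccc([N+](=O)[O-])c1` differs from compound 1 by nitro in place of trifluoromethyl on an aromatic carbon. Among the compounds with values here, no measured step directly concerns a nitro replacing a trifluoromethyl; the three aromatic substitution patterns measured all sit within the scatter of one another, so no step beyond the scatter is expected in this assay. For compound 4 the estimate is 4000 nM, between 1500 nM and 11000 nM, with an expected step of a 1.1-fold lower number from compound 1 to compound 4 (0.04 log units; within the scatter).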

Compound 4, half-maximal inhibitory concentration: 4000 nM
Beside the measured number, compound 4's estimate shows no gap at the digits printed; measured number inside the range.
By their numbers in this assay, from the lowest: compounds 4, 1, 3 and 2 (each within the scatter of the next).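

With nitro in place of trifluoromethyl on the same aromatic carbon, the result is a 1.1-fold lower number from compound 1 to compound 4 (0.04 log units; within the scatter) in this assay. The earlier compounds shown here varied only where trifluoromethyl stood and the presence of fluoro, whereas this step shows that the group itself can be exchanged at this position without a change beyond the scatter. No evidence on any property of these compounds bears on this result. The compounds shown leave open whether an amine or a carboxylic acid on this aromatic carbon would also stay within the scatter of compound 1. From the compounds shown here alone, a longer chain there is equally open.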